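The source may hold more compounds than are shown below. What is called first, only, known or untested is meant among the compounds shown, and "the series" means these compounds.

In a functional assay (Homo sapiens) for inhibition, with a stated time of 72 h (on this read-out higher numbers stand for weaker inhibition and lower numbers for stronger inhibition), compound 1 `COc1cc(C(=O)n2ccc3ccccc32)cc(OC)c1OC` gives > 10000 nM, which is a limit of the assay and not a number. Compound 2 `COc1cc(C(=O)c2cccc3[nH]ccc23)cc(OC)c1OC` gives 51.4 nM, and compound 3 `COc1cc(C(=O)c2ccc3[nH]ccc3c2)cc(OC)c1OC` gives 111 nM. Compound 3 therefore has the higher of the two actual numbers, and its gap to compound 2 lies beyond the usual scatter. Compound 4 `COc1cc(C(=O)c2ccc3c(ccn3C)c2)cc(OC)c1OC` differs from compound 3 in one place: methyl in place of hydrogen on an aromatic nitrogen, with methyl in place of hydrogen on an aromatic nitrogen. For the measured compounds named here, no measured pair shows this change, so in this assay no step beyond the scatter is expected, and no direction can be favoured. The expected step of a 1.1-fold lower number from compound 3 to compound 4 (0.05 log units; within the scatter) is thus small. Compound 4 is estimated at 100 nM, with an expected range from 30 nM to 400 nM.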

Compound 4, half-maximal inhibitory concentration: 12.5 nM
For compound 4 the middle estimate is 8.0-fold (0.90 log units) above the measured one; the measured number lies below the stated range.
By their numbers in this assay, from the lowest: compound 4; then compound 2; then compound 3. At a limit, above all of these: compound 1.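

In this assay methyl in place of hydrogen on the aromatic nitrogen gives an 8.9-fold lower number from compound 3 to compound 4 (0.95 log units; beyond the scatter) and so goes beyond mere tolerance. For compound 3, then, inhibition does not depend on this nitrogen keeping its hydrogen, and a carbon group can sit there with a clear gain. Nothing in the data shown accounts for the size of this step. As far as these compounds go, whether a longer chain such as ethyl, or a chain ending in an amine, would lower the number further on this nitrogen stays open. So does whether methyl would have the same effect on compound 2.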